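This account rests on a few compounds, and the source may have more. Where it says the series, first, only, none or still open, it means among the compounds named here.

Measured so far in an assay on isolated protein for inhibition of Equilibrative nucleoside transporter 1 (Homo sapiens); a lower number here means a stronger inhibitor, a higher number a weaker inhibitor:
compound 1 `OC[C@H]1O[C@@H](n2cnc3c(SCc4ccccc4Cl)ncnc32)[C@H](O)[C@@H]1O`: 117 nM
compound 2 `OC[C@H]1O[C@@H](n2cnc3c(SCc4cccc(Cl)c4)ncnc32)[C@H](O)[C@@H]1O`: 18.2 nM
compound 3 `OC[C@H]1O[C@@H](n2cnc3c(SCc4ccc(Br)cc4)ncnc32)[C@H](O)[C@@H]1O`: 11.5 nM

Compound 2 sits second highest of the three numbers in this assay; its gap to compound 3 is within the scatter, its gap to compound 1 beyond it. Compound 4 `OC[C@H]1O[C@@H](n2cnc3c(SCc4ccccc4I)ncnc32)[C@H](O)[C@@H]1O` differs from compound 2 by 2-iodophenyl in place of 3-chlorophenyl on a saturated chain carbon bound to a sulfur. The step that bears on this is a 6.4-fold lower number from compound 1 to compound 2 (0.81 log units; beyond the scatter), which shows the 2-chlorophenyl analogue weakest; a 10-fold lower number from compound 1 to compound 3 (1.01 log units; beyond the scatter) points the same way. Going back to a 2-halophenyl is therefore expected to raise the number again, roughly undoing that step, though no chlorine-to-iodine comparison exists in the set. The expected step is a 4.4-fold higher number from compound 2 to compound 4 (0.64 log units; beyond the scatter). Compound 4 is estimated at 80 nM, with a range of 25 nM to 250 nM.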

Compound 4, inhibition constant: 19.5 nM
The estimate for compound 4 lay 4.1-fold (0.61 log units) above the measured number, and the stated range ends above it.
By their numbers in this assay, from the lowest: compounds 3, 2 and 4 (each within the scatter of the next); then compound 1.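

In this assay a 2-halophenyl on a saturated chain carbon bound to a sulfur does not by itself carry the higher number of compound 1: iodo in place of chloro on an aromatic carbon gives a 6.0-fold lower number from compound 1 to compound 4 (0.78 log units; beyond the scatter). The 2-iodophenyl group also stays level with the other two halophenyl groups, with a 1.1-fold higher number from compound 2 to compound 4 (0.03 log units; within the scatter) and a 1.7-fold higher number from compound 3 to compound 4 (0.23 log units; within the scatter). No measurement here bears on why iodo and chloro differ.

Open, from the compounds shown here alone, is whether 2-bromophenyl tracks compound 1 or compound 4. Also open, going by these compounds, is how an amine or a carboxylic acid on the phenyl ring would read.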